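This account rests on a few compounds, and the source may have more. Where it says the series, first, only, none or still open, it means among the compounds named here.

Cytotoxicity notes on the 2-methylquinoline ether and amide set, measured in a toxicity assay on HepG2 cells (Homo sapiens) for inhibition, read by CellTiter-Glo, with a stated time of 48 h; a lower number here means a stronger inhibitor, a higher number a weaker inhibitor.

Compound 1 `Cc1cc(C)cc(NC(=O)COc2cc(C)nc3ccccc23)c1` returns only a limit in this assay, > 100000 nM. Compound 2 `COc1ccc2nc(C)cc(NC(=O)C(=O)Nc3cc(C)cc(C)c3)c2c1` likewise gives a limit, > 100000 nM. Going by the values given here, compound 3 `COc1ccc2nc(C)cc(OCC(=O)Nc3cccc(C)c3)c2c1` is the one member with a numerical reading, 39800 nM, and so stands as the sole fixed point against a background where (the limit of > 100000 nM in this assay, at which 2 of the 3 values shown sit). Compound 4 `COc1ccc2nc(C)cc(OCC(=O)Nc3ccc(Cl)cc3Cl)c2c1` has not yet been measured in this assay. It differs from compound 3 in one place: 2,4-dichlorophenyl in place of 3-methylphenyl on an amide-type nitrogen. Among the compounds with values here, no comparable step between measured compounds is available. The expectation is a modest step toward stronger inhibition, a 2.0-fold lower number from compound 3 to compound 4 (0.30 log units; within the scatter), though a result within the scatter of compound 3 would not surprise. Compound 4 is estimated at 20000 nM, with a plausible range from 6000 nM to 70000 nM.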

Compound 4, half-maximal inhibitory concentration: > 100000 nM
Compound 4: a limit, no number (the forecaster's own chance of this, stated with the estimate: 25%); middle value at least 5.0-fold (0.69 log units) from the limit.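

Going by these compounds alone, on the amide-type nitrogen, 2,4-dichlorophenyl in place of 3-methylphenyl gives an at least 2.5-fold higher number from compound 3 to compound 4 (0.40 log units; beyond the scatter) in this assay, the first readable step. Compound 4 gives > 100000 nM, which is a limit and not a number, so the true size of the step stays undefined on its upper side. Compound 3 remains the only member with a numerical reading: the limit of > 100000 nM in this assay, at which 3 of the 4 values shown sit.

As far as these compounds go, the effect of each chlorine alone remains open. Also open, from the compounds shown here alone, is whether an amine or a carboxylic acid on the phenyl group would give a numerical reading.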